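Phenyl on the Methoxy Carbon: What Compound 4 Should Read

A few compounds are considered here, and "the series" means these few. Any claim that something is new, unique, unknown or untested is made for them only; others in the source may bear on it.

Compound 1, `Cc1cccc(C)c1-c1cccc(COc2ccc3c(ccn3CC(=O)O)c2)c1`, gives 3.93 in a physicochemical assay for lipophilicity, measured as octanol-water partition, at pH 7.4; a lower number here means a more polar compound, a higher number a more lipophilic compound.
Compound 2, `O=C(O)CC1COc2cc(OCc3cccc(-c4ccc5sccc5c4)c3)ccc21`, gives 3.97 in this assay.
Compound 3, `COc1ccc(COc2ccc3c(c2)OCC3CC(=O)O)cc1-c1c(C)cccc1C`, gives 3.31 in this assay.

Among these three, compound 3 stands lowest in this assay. Compound 1 lies higher by a margin beyond the scatter, and compound 2 lies higher still, also beyond the scatter. Among the compounds with values here, none of the three differs from another in a single place, so no measured step is available to guide the next move.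

Compound 4, `Cc1cccc(C)c1-c1cc(COc2ccc3c(c2)OCC3CC(=O)O)ccc1OCc1ccccc1`, takes compound 3 and makes one change: phenyl in place of hydrogen on a saturated chain carbon bound to an oxygen on an aromatic ring. Read one bond further out, the methoxy of compound 3 becomes a benzyloxy in compound 4.

Within the data shown here, no measured pair shows this change, so the expectation rests on the size of the added group alone. Compound 4 is expected to move clearly upward in this assay, a step of about a number 1.59 log units higher from compound 3 to compound 4 (beyond the scatter). Compound 4 is therefore estimated at 4.9, with a likely range from 4.3 to 5.5.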

Compound 4, distribution coefficient: 4.53
For compound 4 the middle estimate is 0.37 log units above the measured one, within the range that was stated.
By their numbers in this assay, from the lowest: compound 3; then compounds 1 and 2 (each within the scatter of the next); then compound 4.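

Phenyl in place of hydrogen on a saturated chain carbon bound to an oxygen on an aromatic ring gives the first step in this set between compounds that differ in one place. In this assay this change produces a number 1.22 log units higher from compound 3 to compound 4 (beyond the scatter) and counts as large, so the number is shown to respond strongly at this position, which the earlier compounds could not reveal because none of their pairs isolated a single change. No measurement at hand bears on why the step has this size.

Still open, going by these compounds, is whether a pyridyl ring or a longer alkyl chain at this carbon would produce a step of similar size. Also open, on these data alone, is how an amine or a hydroxyl on the added phenyl would shift the number in this assay relative to compound 4 as it stands.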